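Swapping the pyrimidinyl arm of compound 1 for benzyloxy

A few compounds are considered here, and "the series" means these few. Any claim that something is new, unique, unknown or untested is made for them only; others in the source may bear on it.

Compound 1, `Cc1ccc(-c2ncccn2)c(C(=O)N2CC3(CC3)C[C@H]2CNc2ccc(C(F)(F)F)cn2)n1`, is the strongest of the three measured compounds in a functional assay on CHO cells for antagonist activity at Orexin/Hypocretin receptor type 1 (Homo sapiens), read by FLIPR and calcium flux (a lower number here means a less potent compound, a higher number a more potent compound, by a factor of ten per unit of this negative logarithm), where compound 1 gives 8.4. Compound 3, `O=C(c1ncccc1-c1ncccn1)N1CC2(CC2)C[C@H]1CNc1ccc(C(F)(F)F)cn1`, gives 7.7, and compound 2, `O=C(c1nc(C(F)(F)F)ccc1-c1ncccn1)N1CC2(CC2)C[C@H]1CNc1ccc(C(F)(F)F)cn1`, gives 6.7. The two steps from compound 1 are both beyond the scatter: a number 0.70 log units lower from compound 1 to compound 3 (beyond the scatter) and a number 1.70 log units lower from compound 1 to compound 2 (beyond the scatter), while a number 1.00 log units higher from compound 2 to compound 3 (beyond the scatter). Compound 4, `Cc1ccc(OCc2ccccc2)c(C(=O)N2CC3(CC3)C[C@H]2CNc2ccc(C(F)(F)F)cn2)n1`, keeps the methyl of compound 1 and alters the other arm of the core: benzyloxy in place of pyrimidin-2-yl on an aromatic carbon. Going by the values given here, no measured step touches this position; all three vary only the group para to it, so they show only that this core answers changes with sizeable shifts, and give no direction for the present one. With that in mind, a modest loss in this assay is expected, a number 0.60 log units lower from compound 1 to compound 4 (beyond the scatter). Compound 4 is estimated at 7.8, within a range of 6.8 to 8.6.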

Compound 4, negative logarithm of the antagonist equilibrium constant: 8.6
Compound 4: the middle estimate sits 0.80 log units below what was measured; low and high end bracket the measured number.
By their numbers in this assay, from the lowest: compound 2; then compound 3; then compounds 1 and 4 (each within the scatter of the next).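

In this assay, the position ortho to a large group on the core of compound 1 accepts benzyloxy in place of pyrimidin-2-yl with no readable change (a number 0.20 log units higher from compound 1 to compound 4 (within the scatter)). Benzyloxy brings 8 heavy atoms where pyrimidin-2-yl had 6, and a ring of carbon only where that group had 2 hetero atoms, so neither of these differences moves the number beyond the scatter. The earlier steps shown here, all at the methyl group, each shifted the number beyond the scatter, whereas this exchange at the other arm does not.

Still open, going by these compounds, is whether an amine, a carboxylic acid or a longer alkoxy chain would be accepted here, and whether benzyloxy would fare the same with hydrogen or trifluoromethyl in place of the methyl group. Nothing shown here explains why the two groups give numbers so close together.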